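The compounds below may be only part of what the source reports. "The series", "measured", "known", "first", "only" and "open" are said of these compounds alone.

Measured in a toxicity assay on the whole organism (strain Icem-CET (SPF Caw)) for cytotoxicity, with Mus musculus as the target; a higher number here means that more compound is needed for the effect, a lower number that less compound is needed:
Compound 1 `C/C(C(=O)NC1CC1)=C(/C)c1ccc(F)cc1` gives 70 mg/kg in this assay.
Compound 2 `C/C(C(=O)NC1CC1)=C(/C)c1ccccc1` gives 150 mg/kg in this assay.

Compound 2 stands with the highest of the two numbers measured; its nearest neighbour, compound 1, lies lower by a 2.1-fold higher number from compound 1 to compound 2 (0.33 log units; beyond the scatter), a step that swaps hydrogen for fluoro on an aromatic carbon.

Compound 3 `COc1ccc(/C(C)=C(\C)C(=O)NC2CC2)cc1` is not yet measured in this assay. It differs from compound 2 by methoxy in place of hydrogen on an aromatic carbon. Within the data shown here, only one measured step exists, and it concerns fluoro against hydrogen at that aromatic carbon, not methoxy; it was modest, moving the number from compound 1 to compound 2 by a 2.1-fold higher number from compound 1 to compound 2 (0.33 log units; beyond the scatter). Among the measured compounds shown here, no measured step covers methoxy, so the direction for compound 3 is uncertain. A small change is expected, probably downward towards compound 1 and possibly within the scatter, meaning an estimated step of a 1.5-fold lower number from compound 2 to compound 3 (0.18 log units; within the scatter). The estimate for compound 3 in this assay is 100 mg/kg, with a range of 50 mg/kg to 220 mg/kg.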

Compound 3, dose for half-maximal effect: 250 mg/kg
Compound 3: middle estimate off by 2.5-fold (0.40 log units), on the low side; measured number outside the range, above it.
By their numbers in this assay, from the lowest: compound 1; then compounds 2 and 3 (each within the scatter of the next).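

In this assay, methoxy in place of hydrogen on the aromatic carbon para to a large group gives a 1.7-fold higher number from compound 2 to compound 3 (0.22 log units; within the scatter), so this larger substituent, with its oxygen and hydrogen-bond acceptor, does not separate the two compounds. Methoxy in place of fluoro at the same carbon gives a 3.6-fold higher number from compound 1 to compound 3 (0.55 log units; beyond the scatter), which leaves compound 1, the fluoro member, as the only one of the three standing apart from both others, while the hydrogen and methoxy members stay together.

On these data alone, three substituents at one carbon cannot show whether this separation belongs to fluoro alone or extends to chloro, and an amine, a carboxylic acid or a longer alkoxy chain such as ethoxy remains untested here. Changes elsewhere on the shared core also remain open. No measurement available here offers an explanation for these numbers.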